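Compound 3 to compound 4: a carbonyl group gives way

A few compounds are considered here, and "the series" means these few. Any claim that something is new, unique, unknown or untested is made for them only; others in the source may bear on it.

Of the compounds shown here, three sharing one core have been measured in a functional assay on VCaP cells (Homo sapiens) for antiproliferative activity, read by CCK-8 assay, with a stated time of 6 days; a higher number here means a weaker inhibitor, a lower number a stronger inhibitor. Compound 1 `COc1ccc(C(=O)N[C@@H](C)Cn2ccc(-c3ccc(C#N)c(Cl)c3)n2)cc1` gives 1540 nM, compound 2 `COC(=O)/C=C/C(=O)N[C@@H](C)Cn1ccc(-c2ccc(C#N)c(Cl)c2)n1` gives 5230 nM, and compound 3 `C[C@@H](Cn1ccc(-c2ccc(C#N)c(Cl)c2)n1)NC(=O)C1CC(=O)C1` gives 22500 nM. That last number is the highest of the three, making compound 3 the weakest inhibitor so far.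

Compound 4 `C[C@@H](Cn1ccc(-c2ccc(C#N)c(Cl)c2)n1)Nc1cncnc1` carries pyrimidin-5-yl in place of (3-oxocyclobutyl)carbonyl on an amine nitrogen. Among the compounds with values here, no measured step makes this exact change, since all three swap only the group on a carbonyl carbon, and none removes the carbonyl. They bear on it indirectly, showing how far the number moves when this part of the molecule changes. The measured steps are a 3.4-fold higher number from compound 1 to compound 2 (0.53 log units; beyond the scatter), a 4.3-fold higher number from compound 2 to compound 3 (0.63 log units; beyond the scatter) and, the largest, a 15-fold higher number from compound 1 to compound 3 (1.16 log units; beyond the scatter).

Compound 3 stands at the top of this short range, and an aromatic ring enters in compound 4. Within the data shown here, the one measured aromatic example, compound 1, gives 1540 nM. A modest move toward a lower number in this assay is therefore expected, though with wide uncertainty. The expected step is a 2.8-fold lower number from compound 3 to compound 4 (0.45 log units; beyond the scatter). Compound 4 is estimated at 8000 nM, with an expected range from 1800 nM to 35000 nM.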

Compound 4, half-maximal inhibitory concentration: > 30000 nM
Compound 4 ended at the assay's limit (the forecaster's own chance of this, stated with the estimate: 15%); at least 3.7-fold (0.57 log units) between middle value and limit.
By their numbers in this assay, from the lowest: compound 1; then compound 2; then compound 3. At a limit, above all of these: compound 4.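

In this assay, compound 4 ended at a limit, which is not a number: the limit of > 30000 nM in this assay, at which 1 of the 4 values shown sits. Within the data shown here, at this position the result gives an at least 1.3-fold higher number from compound 3 to compound 4 (0.12 log units; that floor lies within the scatter) and an at least 5.7-fold higher number from compound 2 to compound 4 (0.75 log units; beyond the scatter), so the first compound with no carbonyl on this nitrogen gives no sign of a move toward a lower number from either neighbour, although the floor of the first step cannot separate compound 3 from compound 4. An aromatic ring alone therefore did not bring a strong result with it here: compound 1 gives 1540 nM with 4-methoxyphenyl on a carbonyl carbon, while compound 4 carries its pyrimidin-5-yl directly on an amine nitrogen.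

The compounds shown change the ring and remove the carbonyl in one move, so they cannot say which of the two changes matters more; pyrimidin-5-yl on a carbonyl carbon, or a plain phenyl on the amine nitrogen, would separate them. From the compounds shown here alone, how far compound 4 actually lies from compound 3 also stays open, since only a floor on that step can be read.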